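Changing the aromatic group on the ring amine nitrogen

A few compounds are considered here, and "the series" means these few. Any claim that something is new, unique, unknown or untested is made for them only; others in the source may bear on it.

Compound 1 `COC(=O)C1=C(C)NC(=O)N(C(=O)NCCCN2CCN(c3ccccc3OC)CC2)C1c1ccc(F)c(F)c1` and compound 2 `COC(=O)C1=C(C)NC(=O)N(C(=O)NCCCN2CCN(c3ccccc3O)CC2)C1c1ccc(F)c(F)c1` share the same core and differ only in one substituent on an aromatic ring. In an assay on liver for binding affinity to Alpha-1D adrenergic receptor (Homo sapiens), using microsomes (a lower number here means a stronger inhibitor, a higher number a weaker inhibitor), compound 1 gives 31 nM, and compound 2 gives 31 nM; the step of no change at the digits printed from compound 1 to compound 2 (within the scatter) shows that putting a hydrogen in place of the methyl on that oxygen leaves binding where it was. Compound 2 therefore stands level with compound 1 on the numbers available.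

Compound 3 `COC(=O)C1=C(C)NC(=O)N(C(=O)NCCCN2CCN(c3ccc(Cl)cc3)CC2)C1c1ccc(F)c(F)c1` is the next compound to be measured. Its change from compound 2 is 4-chlorophenyl in place of 2-hydroxyphenyl on an amine nitrogen in a ring, which removes the hydroxyl group and brings in a chlorine. Within the data shown here, the only measured step, from compound 1 to compound 2, concerns the same ring but altered only the group on the oxygen, and it stayed within the scatter; no measured step tests losing the oxygen altogether or adding the chlorine. The expectation is therefore uncertain, leaning toward a modest loss, an estimated step of a 2.6-fold higher number from compound 2 to compound 3 (0.41 log units; beyond the scatter). For compound 3 in this assay the estimate is 80 nM, within a range of 20 nM to 400 nM.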

Compound 3, inhibition constant: 52 nM
For compound 3 the middle estimate is 1.5-fold (0.19 log units) above the measured one, and the stated range covers the measured number.
By their numbers in this assay, from the lowest: compounds 1, 2 and 3 (each within the scatter of the next).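

In this assay, the aromatic group on the ring amine nitrogen can be exchanged more widely than the first pair revealed: there is a 1.7-fold higher number from compound 2 to compound 3 (0.22 log units; within the scatter) and a 1.7-fold higher number from compound 1 to compound 3 (0.22 log units; within the scatter), so 4-chlorophenyl cannot be told apart here from either 2-hydroxyphenyl or 2-methoxyphenyl. The step from compound 1 to compound 2 altered only what sits on the oxygen, whereas compound 3 has no oxygen on this ring at all, which shows that binding in this range does not depend on keeping that oxygen in this series. Nothing available explains why binding holds up across this exchange.

The exchange in compound 3 alters both the kind of substituent and where it sits on the ring, so the effects of the two cannot be separated; 2-chlorophenyl, with chlorine in the same numbered position as the earlier groups, would pull them apart. From the compounds shown here alone, it also remains open whether the position accepts an unsubstituted phenyl, a ring bearing an amine or a carboxylic acid, or a group that is not aromatic, such as cyclohexyl.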